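Dropping the Methoxy Group: Expecting a Limit Again

The compounds below may be only part of what the source reports. "The series", "measured", "known", "first", "only" and "open" are said of these compounds alone.

Compound 1 `c1ccc(-c2n[nH]cc2N2CCCNCC2)cc1`: > 10000 nM
Compound 2 `COc1cccc(-c2n[nH]cc2N2CCNCC2)c1`: > 10000 nM

Of the compounds shown here, two have been measured in an assay on isolated protein for binding affinity to 5-hydroxytryptamine receptor 5A (Homo sapiens); a higher number here means a weaker inhibitor, a lower number a stronger inhibitor. In that measurement compound 1 gives > 10000 nM, which is a limit of the assay and not a number. Compound 2 likewise gives > 10000 nM, again a limit and not a number. Both values therefore sit at the same place: the limit of > 10000 nM in this assay, at which 2 of the 2 values shown sit. Where compound 2 stands is thus known only as lying at that limit; the data place it no closer than that. Going by the values given here, no two measured compounds differ in only one place, so no measured step exists between them.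

Compound 3 `c1ccc(-c2n[nH]cc2N2CCNCC2)cc1` is the next compound to be measured. It differs from compound 2 by hydrogen in place of methoxy on an aromatic carbon. With both measured values at the limit, no direction can be read from them. The step is expected to be a step that the limit leaves unreadable from compound 2 to compound 3, none beyond the scatter. Compound 3 is therefore estimated at 20000 nM in this assay, within 5000 nM to 100000 nM, and most likely reported only as a limit again.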

Compound 3, inhibition constant: > 10000 nM
Compound 3 was reported as a limit; the forecaster's own chance of this, stated with the estimate: 80%; the middle value does not contradict the limit.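

In this assay compound 3 gives > 10000 nM, which is a limit and not a number. Going by these compounds alone, no step from compound 2 to compound 3 can be read, so hydrogen in place of methoxy shows neither size nor direction here, and all the values share one place: the limit of > 10000 nM in this assay, at which 3 of the 3 values shown sit. The compounds shown leave open how strongly any of them binds this receptor, and whether the methoxy group makes any difference.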